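Nitro in Place of Fluoro: What to Expect for Compound 4

This account rests on a few compounds, and the source may have more. Where it says the series, first, only, none or still open, it means among the compounds named here.

Compound 3 `CCCn1c(=O)c2nc(-c3ccc(OCC(=O)NCCN=C(S)Nc4ccc(F)cc4)cc3)[nH]c2n(CCC)c1=O` gives 15.5 nM in an assay on brain for binding affinity to adenosine receptor A1 (Rattus norvegicus), read by radioligand binding; on this read-out lower numbers stand for stronger inhibition and higher numbers for weaker inhibition. Among the three measured numbers it stands second highest: compound 1 `CCCn1c(=O)c2nc(-c3ccc(OCC(=O)NCCN=C(S)Nc4ccc(N=C=S)cc4)cc3)[nH]c2n(CCC)c1=O` gives 6.6 nM, and compound 2 `CCCn1c(=O)c2nc(-c3ccc(OCC(=O)NCCN=C(S)Nc4ccc(OC)cc4)cc3)[nH]c2n(CCC)c1=O` gives 33.2 nM. The change leading to compound 4 `CCCn1c(=O)c2nc(-c3ccc(OCC(=O)NCCN=C(S)Nc4ccc([N+](=O)[O-])cc4)cc3)[nH]c2n(CCC)c1=O` is nitro in place of fluoro on an aromatic carbon. The measured steps at this same position move in both directions and stay modest: a 2.3-fold higher number from compound 1 to compound 3 (0.37 log units; beyond the scatter), while a 2.1-fold lower number from compound 2 to compound 3 (0.33 log units; beyond the scatter). None of them involves a nitro group, so they only show that swaps here shift the number by small amounts. For compound 4 the expected step is a 1.3-fold lower number from compound 3 to compound 4 (0.11 log units; within the scatter), which need not exceed the scatter. The estimate for compound 4 is 12 nM, within a range from 4 nM to 35 nM.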

Compound 4, inhibition constant: 15.9 nM
Beside the measured number, compound 4's estimate is 1.3-fold (0.12 log units) below it; low and high end bracket the measured number.
By their numbers in this assay, from the lowest: compound 1; then compounds 3 and 4 (each within the scatter of the next); then compound 2.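

In this assay, a nitro group with more heavy atoms than fluoro, and with hydrogen-bond acceptors that fluoro lacks, gives no step beyond the scatter (a 1.0-fold higher number from compound 3 to compound 4 (0.01 log units; within the scatter)). Compound 4 therefore sits among the other compounds much as compound 3 does, with a lower number than the methoxy compound (a 2.1-fold lower number from compound 2 to compound 4 (0.32 log units; beyond the scatter)) and a higher one than the isothiocyanate-bearing compound (a 2.4-fold higher number from compound 1 to compound 4 (0.38 log units; beyond the scatter)). Nothing available explains why these two groups match. Going by these compounds, whether an amine or a carboxylic acid on this aromatic carbon would also leave the number unchanged remains open.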